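From methoxycarbonyl to benzyloxycarbonyl: an expected shift

This account rests on a few compounds, and the source may have more. Where it says the series, first, only, none or still open, it means among the compounds named here.

Measured in a functional assay on PC-3 cells (Homo sapiens) for cytotoxicity, read by MTT assay, with a stated time of 72 h; on this read-out lower numbers stand for stronger inhibition and higher numbers for weaker inhibition:
Compound 1 `COC(=O)c1ccc(/C=C/C(=O)c2cc(OC)ccc2OC)cc1`: 4850 nM
Compound 2 `CCCOC(=O)c1ccc(/C=C/C(=O)c2cc(OC)ccc2OC)cc1`: 26900 nM
Compound 3 `COc1ccc(OC)c(C(=O)/C=C/c2ccc(C(=O)OC(C)C)cc2)c1`: 6740 nM

These numbers put compound 1 at the low end, with a close neighbour: a 1.4-fold higher number from compound 1 to compound 3 (0.14 log units; within the scatter). Compound 4 `COc1ccc(OC)c(C(=O)/C=C/c2ccc(C(=O)OCc3ccccc3)cc2)c1`, not yet measured, carries phenyl in place of hydrogen on a saturated chain carbon bound to an oxygen next to a carbonyl group. The closest guide, with ethyl entering at that same place, is a 5.5-fold higher number from compound 1 to compound 2 (0.74 log units; beyond the scatter). Compound 3 tempers this guide: a 4.0-fold lower number from compound 2 to compound 3 (0.60 log units; beyond the scatter). Nothing with a ring at this place has been measured, so only a modest rise in this assay is expected. The expected step is a 2.3-fold higher number from compound 1 to compound 4 (0.36 log units; beyond the scatter). Compound 4 is estimated at 11000 nM, with an expected range of 3500 nM to 32000 nM.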

Compound 4, half-maximal inhibitory concentration: 18000 nM
The estimate for compound 4 lay 1.6-fold (0.21 log units) below the measured number; the measured number falls inside the stated range.
By their numbers in this assay, from the lowest: compounds 1 and 3 (each within the scatter of the next); then compounds 4 and 2 (each within the scatter of the next).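

In this assay, phenyl on this saturated chain carbon carries a cost, as ethyl did, with a 3.7-fold higher number from compound 1 to compound 4 (0.57 log units; beyond the scatter). The benzyl group also falls short of the branched isopropyl group on the same oxygen, with a 2.7-fold higher number from compound 3 to compound 4 (0.43 log units; beyond the scatter), while the ring and the straight propyl chain cannot be told apart, with a 1.5-fold lower number from compound 2 to compound 4 (0.17 log units; within the scatter). Nothing available here accounts for these differences. The compounds shown leave open how a longer chain ending in phenyl, such as phenethyl, would compare. They also leave open what a free carboxylic acid or an amide would do in place of this ester.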